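This account rests on a few compounds, and the source may have more. Where it says the series, first, only, none or still open, it means among the compounds named here.

Measured so far in a functional assay on RS4-11 cells (Homo sapiens) for inhibition, read by CCK-8 assay, with a stated time of 72 h; on this read-out lower numbers stand for stronger inhibition and higher numbers for weaker inhibition:
- compound 1 `CC1(C)CCC(CN2CCN(c3ccc(C(=O)NS(=O)(=O)c4ccc(NC5CCOC5)c([N+](=O)[O-])c4)c(Oc4cnc5[nH]ccc5c4)c3)CC2)=C(c2ccc(C(F)(F)F)cc2)C1`: 32 nM
- compound 2 `CC1(C)CCC(CN2CCN(c3ccc(C(=O)NS(=O)(=O)c4ccc(OCC5CCCOC5)c([N+](=O)[O-])c4)c(Oc4cnc5[nH]ccc5c4)c3)CC2)=C(c2ccc(C(F)(F)F)cc2)C1`: 12 nM

Of these two, compound 2 gives the lower number, at 12 nM. Compound 3 `CN1CCC(COc2ccc(S(=O)(=O)NC(=O)c3ccc(N4CCN(CC5=C(c6ccc(C(F)(F)F)cc6)CC(C)(C)CC5)CC4)cc3Oc3cnc4[nH]ccc4c3)cc2[N+](=O)[O-])C1` keeps the core of compound 2 and alters one group: 1-methylpyrrolidin-3-yl in place of oxan-3-yl on a saturated chain carbon bound to an oxygen on an aromatic ring. Read one bond further out, this is (oxan-3-yl)methyl to (1-methylpyrrolidin-3-yl)methyl.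

Within the data shown here, only one measured step bears on this change, and only indirectly: a 2.7-fold lower number from compound 1 to compound 2 (0.43 log units; beyond the scatter). That modest step exchanged a different pair of groups on the same aromatic carbon. Among the measured compounds shown here, no measured compound carries 1-methylpyrrolidin-3-yl, so the direction is uncertain. A step of similar modest size is expected at most, leaning towards a higher number. The expected change is a 1.7-fold higher number from compound 2 to compound 3 (0.22 log units; within the scatter). In this assay, compound 3 is estimated at 20 nM, with an expected range of 6 nM to 65 nM.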

Compound 3, half-maximal inhibitory concentration: 10 nM
The estimate for compound 3 lay 2.0-fold (0.30 log units) above the measured number, and the stated range covers the measured number.
By their numbers in this assay, from the lowest: compounds 3 and 2 (each within the scatter of the next); then compound 1.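

In this assay, placing 1-methylpyrrolidin-3-yl for oxan-3-yl on a saturated chain carbon bound to an oxygen on an aromatic ring gives a 1.2-fold lower number from compound 2 to compound 3 (0.08 log units; within the scatter), so this assay does not tell the two rings apart, and a ring nitrogen carrying a methyl group serves here as well as the ring oxygen. The wider change of (oxolan-3-yl)amino to (1-methylpyrrolidin-3-yl)methoxy on an aromatic carbon gives a 3.2-fold lower number from compound 1 to compound 3 (0.51 log units; beyond the scatter), so compound 3 joins compound 2 on the same side of the gap to compound 1. The data offer no measurement that accounts for either step.

From the compounds shown here alone, it remains open whether a pyrrolidin-3-yl ring without the methyl group, a piperidine ring or a carboxylic acid on that chain carbon would give a similar number. The compounds shown also do not separate the amino link from the methoxy link with the same ring held in place.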